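Triple-bond substituent change from compound 2 to compound 3

This account rests on a few compounds, and the source may have more. Where it says the series, first, only, none or still open, it means among the compounds named here.

Measured so far in an ADME assay (liver) for metabolic stability, with Liver microsome (Homo sapiens) as the target, using microsomes and NADPH, with a stated time of 30 min, tested at 1 uM; on this read-out lower numbers stand for slow clearance and higher numbers for fast clearance:
- compound 1 `Nc1ccc(S(=O)(=O)N2CCN(c3ncc(C(O)(C(F)(F)F)C(F)(F)F)cc3C#CC3CC3)CC2)cn1`: < 14 mL.min-1.g-1 (a limit of the assay, not a number)
- compound 2 `COCC#Cc1cc(C(O)(C(F)(F)F)C(F)(F)F)cnc1N1CCN(S(=O)(=O)c2ccc(N)nc2)CC1`: 15 mL.min-1.g-1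

Within the data shown here, compound 2 holds the only true number in this small set, so it has no measured neighbour to be ranked against. The other reference point is the limit of < 14 mL.min-1.g-1 in this assay, at which 1 of the 2 values shown sits.

The next compound is compound 3 `CC(C)(O)C#Cc1cc(C(O)(C(F)(F)F)C(F)(F)F)cnc1N1CCN(S(=O)(=O)c2ccc(N)nc2)CC1`. Relative to compound 2, it has 1-hydroxy-1-methylethyl in place of methoxymethyl on a triple-bonded carbon. In the longer reading, 3-methoxyprop-1-yn-1-yl gives way to 3-hydroxy-3-methylbut-1-yn-1-yl.

Among the measured compounds shown here, only one measured step bears on this change, and it is a swap at the same place: an at least 1.0-fold higher number from compound 1 to compound 2 (0.02 log units; that floor lies within the scatter). That single step offers a floor and no true size, so the guidance is weak. On this basis, no step beyond the scatter is expected in this assay, in either direction. The expected change is no change at the digits printed from compound 2 to compound 3 (within the scatter). A report of a limit instead of a number would not be a surprise for compound 3. The estimated value for compound 3 is 15 mL.min-1.g-1, with an expected range from 9 mL.min-1.g-1 to 26 mL.min-1.g-1.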

Compound 3, intrinsic clearance in microsomes: < 14 mL.min-1.g-1
Compound 3 was reported as a limit; the forecaster's own chance of this, stated with the estimate: 40%; middle value at least 1.0-fold (0.02 log units) away from the limit.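

In this assay compound 3 gives < 14 mL.min-1.g-1, which is a limit and not a number. Placing 1-hydroxy-1-methylethyl in place of methoxymethyl on a triple-bonded carbon gives an at least 1.0-fold lower number from compound 2 to compound 3 (0.02 log units; that floor lies within the scatter), so this position now holds a group with a hydrogen-bond donor, and no step beyond the scatter can be read from this change. Neither readable step at this position goes beyond the scatter, and most of the series now sits at the limit: the limit of < 14 mL.min-1.g-1 in this assay, at which 2 of the 3 values shown sit.

The step between compound 1 and compound 3 cannot be read, as both are limits, so no order can be drawn among cyclopropyl, methoxymethyl and 1-hydroxy-1-methylethyl at this position. Going by these compounds, whether an amine, a carboxylic acid or a longer chain on the triple-bonded carbon would give a number clearly separated from the limit remains open.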